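The source may hold more compounds than are shown below. What is called first, only, known or untested is meant among the compounds shown, and "the series" means these compounds.

Measured compounds:

- compound 1, `Cc1cc(NC(=O)CN2CCC(c3cccc[n+]3[O-])CC2)ccc1F`, in a functional assay on HEK293 cells for agonist activity at D(4) dopamine receptor (Homo sapiens), read by FLIPR (on this read-out higher numbers stand for an effect only at larger amounts of compound and lower numbers for an effect already at smaller amounts), gives 18 nM
- compound 2, `C=Cc1cccc(C(=O)NCN2CCC(c3cccc[n+]3[O-])CC2)c1`, in this assay gives 68 nM
- compound 3, `N#Cc1cccc(C(=O)NCN2CCC(c3cccc[n+]3[O-])CC2)c1`, in this assay gives 840 nM

Among these three numbers, compound 3 stands highest: the gap to compound 2 is the nearest, and the gap to compound 1 is the widest, both beyond the scatter. Among the compounds with values here, the only single-point step measured so far is a 12-fold higher number from compound 2 to compound 3 (1.09 log units; beyond the scatter), which shows that putting a nitrile onto the ring attached to the carbonyl carbon drove the number sharply upward.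

Compound 4, `O=C(NCN1CCC(c2cccc[n+]2[O-])CC1)c1cnccc1Cl`, is not yet measured. It differs from compound 3 in one place: 4-chloropyridin-3-yl in place of 3-cyanophenyl on a carbonyl carbon. Within the data shown here, no measured step exchanges one whole aromatic ring for another, so there is no direct precedent. What the data do show is that compound 3 carries the nitrile that coincided with the large rise, and compound 4 no longer carries it. Among the measured compounds shown here, on that basis the number for compound 4 is expected to come down, a step of about a 3.4-fold lower number from compound 3 to compound 4 (0.53 log units; beyond the scatter), though the new ring with its chlorine and ring nitrogen has no measured counterpart, so the range is wide. The estimate for compound 4 in this assay is 250 nM, between 60 nM and 1000 nM.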

Compound 4, half-maximal effective concentration: 1290 nM
For compound 4 the middle estimate is 5.2-fold (0.71 log units) below the measured one; the measured number lies above the stated range.
By their numbers in this assay, from the lowest: compound 1; then compound 2; then compounds 3 and 4 (each within the scatter of the next).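

In this assay, the exchange of 3-cyanophenyl for 4-chloropyridin-3-yl on the carbonyl carbon gives a 1.5-fold higher number from compound 3 to compound 4 (0.19 log units; within the scatter) and so stays inside the scatter, which means that a number of this size does not require the nitrile. Set against the ring with the vinyl group, the same new ring gives a 19-fold higher number from compound 2 to compound 4 (1.28 log units; beyond the scatter) and thus falls in with the nitrile compound, so that among these three the ring carrying the vinyl group alone stands apart. Nothing measured here explains either step. Which part of the new ring matters remains open, as no compound shown carries its chlorine without its ring nitrogen. Also open, as far as these compounds go, is how an ethyl, a methoxy or an amine would behave where the vinyl group sits on this ring.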